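Third methoxy on the aryl ring of compound 3

The source may report more compounds than this note shows. Statements on the series, on what has been measured and on what is new or still open speak of the compounds shown alone.

Working notes on the series. Three compounds have numbers in a functional assay on 786-0 cells (Homo sapiens) for inhibition, read by sulforhodamine B assay, with a stated time of 48 h; on this read-out higher numbers stand for weaker inhibition of growth and lower numbers for stronger inhibition of growth. Compound 1 `COc1cc(/C=C/C2CC(=O)C=CO2)cc(OC)c1OC` gives 125 uM. Compound 2 `COc1ccc(/C=C/C2CC=CC(=O)O2)cc1OC` gives 10.9 uM. Compound 3 `COc1cc(/C=C/C2CC=CC(=O)O2)cc(OC)c1` gives 10.6 uM, the lowest of the three numbers; compound 2 sits nearest, within the scatter, so no order between compound 2 and compound 3 can be read from them, while compound 1 stands furthest, beyond the scatter. Compound 1 differs from compound 3 in more than one place, so its gap tells nothing of any single change.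

The next compound is compound 4 `COc1cc(/C=C/C2CC=CC(=O)O2)cc(OC)c1OC`. It differs from compound 3 in one place: methoxy in place of hydrogen on an aromatic carbon. Among the measured compounds shown here, no measured pair in this assay shows that same change, so the step is judged without a precedent. Compound 2 and compound 3 carry two methoxy groups each and give much the same number, which suggests the count of methoxy groups has not been decisive so far; a third one is expected to move the number little, and in either direction within a modest span. The step from compound 3 to compound 4 is estimated at a 1.4-fold higher number from compound 3 to compound 4 (0.15 log units; within the scatter). For compound 4 the expected value is 15 uM, within a range of 5 uM to 60 uM.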

Compound 4, concentration for growth inhibition (reported as GI): 18.5 uM
Beside the measured number, compound 4's estimate is 1.2-fold (0.09 log units) below it; the measured number falls inside the stated range.
By their numbers in this assay, from the lowest: compounds 3, 2 and 4 (each within the scatter of the next); then compound 1.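

In this assay, methoxy in place of hydrogen, ortho to two methoxy groups, gives a 1.7-fold higher number from compound 3 to compound 4 (0.24 log units; within the scatter), and the same kind of change from the other dimethoxy compound gives a 1.7-fold higher number from compound 2 to compound 4 (0.23 log units; within the scatter), so this position accepts a third methoxy without a step beyond the scatter. Among the compounds shown here, with the same trimethoxy aryl ring on both sides, exchanging one six-membered non-aromatic ring for the other gives a 6.8-fold lower number from compound 1 to compound 4 (0.83 log units; beyond the scatter), the only step here beyond the scatter, which places the larger difference in that ring exchange and not in the methoxy change. Nothing available explains either result.

Open, on these data alone, is whether a hydroxy group, an amine or a longer chain such as ethoxy on this aromatic carbon would stay within the scatter of compound 3. Also open, as far as these compounds go, is whether the ring exchange would give a similar step on a dimethoxy aryl ring.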